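Fluoro to chloro on compound 2

A few compounds are considered here, and "the series" means these few. Any claim that something is new, unique, unknown or untested is made for them only; others in the source may bear on it.

Compound 1 `CCCC(C)Oc1ccc(C(=O)/C=C/c2c(/C=C/c3ccc(OC)cc3)cc(OC)cc2OC)cc1`: 11.1 ug/mL
Compound 2 `COc1ccc(/C=C/c2cc(OC)cc(OC)c2/C=C/C(=O)c2ccc(F)cc2)cc1`: 12.2 ug/mL

In a functional assay on HepG2 cells (Homo sapiens) for antiproliferative activity, read by MTT assay, with a stated time of 48 h (a lower number here means a stronger inhibitor, a higher number a weaker inhibitor), compound 2 gives 12.2 ug/mL and compound 1 gives 11.1 ug/mL, so the two stand within the scatter of each other. Compound 3 `COc1ccc(/C=C/c2cc(OC)cc(OC)c2/C=C/C(=O)c2ccc(Cl)cc2)cc1` carries chloro in place of fluoro on an aromatic carbon, para to a large group: chloro in place of fluoro on an aromatic carbon. For the measured compounds named here, the one measured step at this carbon, a 1.1-fold higher number from compound 1 to compound 2 (0.04 log units; within the scatter), exchanged 1-methylbutoxy for fluoro and stayed within the scatter. Going by the values given here, no measured compound yet tests chloro there, so no change beyond the scatter is expected in this assay, in either direction. The expected step is a 1.1-fold lower number from compound 2 to compound 3 (0.04 log units; within the scatter). Compound 3 is estimated at 11 ug/mL, with an expected range of 5.5 ug/mL to 22 ug/mL.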

Compound 3, half-maximal inhibitory concentration: 13.6 ug/mL
The estimate for compound 3 lay 1.2-fold (0.09 log units) below the measured number; the measured number falls inside the stated range.
By their numbers in this assay, from the lowest: compounds 1, 2 and 3 (each within the scatter of the next).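

In this assay chloro in place of fluoro on this aromatic carbon gives a 1.1-fold higher number from compound 2 to compound 3 (0.05 log units; within the scatter) and chloro in place of 1-methylbutoxy gives a 1.2-fold higher number from compound 1 to compound 3 (0.09 log units; within the scatter), both within the scatter. Three groups have now been compared at this carbon, para to a large group, and none stands apart from the others. Nothing available bears on the reason for this result. On these data alone, whether a primary amine, a carboxylic acid or a longer alkoxy chain at this carbon would move the number beyond the scatter remains open.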